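This account rests on a few compounds, and the source may have more. Where it says the series, first, only, none or still open, it means among the compounds named here.

Measured in a functional assay on A-375 cells (Homo sapiens) for activation, with a stated time of 3 days; on this read-out lower numbers stand for an effect already at smaller amounts and higher numbers for an effect only at larger amounts of compound:
- compound 1 `O=C(Nc1ccc(-c2nccs2)cc1)C1CCCN(Cc2ccc(F)c(F)c2)C1`: 800 nM
- compound 2 `O=C(Nc1ccc(-c2ccco2)cc1)C1CCCN(Cc2ccc(F)c(F)c2)C1`: 2200 nM

Not yet measured: compound 3 `O=C(Nc1ccc(-c2ccsc2)cc1)C1CCCN(Cc2ccc(F)c(F)c2)C1`.

Going by the values given here, of the two measured compounds, compound 2 has the higher number, at 2200 nM, and its only neighbour is compound 1 at 800 nM. The next change replaces furan-2-yl with thiophen-3-yl on an aromatic carbon, para to a large group: thiophen-3-yl in place of furan-2-yl on an aromatic carbon. The ring size and the counted donors and acceptors stay the same, while oxygen gives way to sulfur.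

Among the compounds with values here, only one measured step bears on this change: a 2.8-fold higher number from compound 1 to compound 2 (0.44 log units; beyond the scatter). It is modest but beyond the scatter, and it runs from a sulfur-containing ring to furan-2-yl. Within the data shown here, a single step sets no rule, and no thiophen-3-yl compound has been measured yet, so only part of that gap is expected to close in this assay. The expected change is small, towards a lower number, and not clearly beyond the scatter: a 1.7-fold lower number from compound 2 to compound 3 (0.23 log units; within the scatter). For compound 3 the estimate is 1300 nM, with an expected range of 500 nM to 3500 nM.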

Compound 3, half-maximal effective concentration: 1930 nM
Compound 3: the middle estimate sits 1.5-fold (0.17 log units) below what was measured; low and high end bracket the measured number.
By their numbers in this assay, from the lowest: compound 1; then compounds 3 and 2 (each within the scatter of the next).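

In this assay, replacing furan-2-yl with thiophen-3-yl on this aromatic carbon, para to a large group, gives a 1.1-fold lower number from compound 2 to compound 3 (0.06 log units; within the scatter), so this exchange of oxygen for sulfur, with ring size and counted donors and acceptors unchanged, has no readable effect on the number. The 1,3-thiazol-2-yl group remains distinct from thiophen-3-yl, with a 2.4-fold higher number from compound 1 to compound 3 (0.38 log units; beyond the scatter), and a ring sulfur alone therefore does not track with the lower number of compound 1: compound 3 also carries sulfur yet stays within the scatter of the furan compound 2. No supporting data are available to explain either step.

Open, going by these compounds, is what sets compound 1 apart: 1,3-thiazol-2-yl differs from thiophen-3-yl both in its ring nitrogen and in its point of attachment, and thiophen-2-yl and 1,3-oxazol-2-yl would help separate the two. Also open, on these data alone, is whether a six-membered pyridin-2-yl ring or a non-aromatic group such as an amine at this position would keep the number in the same range.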